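Aminoindazole series: trimming the pyrrolidine amine

The source may report more compounds than this note shows. Statements on the series, on what has been measured and on what is new or still open speak of the compounds shown alone.

Working notes on a small set of indazoles in an assay on isolated protein for inhibition of tyrosine-protein kinase receptor UFO (Homo sapiens), with a stated time of 1.5 h; on this read-out higher numbers stand for weaker inhibition and lower numbers for stronger inhibition. Compound 1 `Clc1cc2[nH]nc(-c3cnn(-c4ccccc4)c3)c2cc1N[C@@H]1CCNC1` gives 1700 nM. Compound 3 `CNC1CCN(c2ccc3[nH]nc(-c4cnn(C)c4)c3c2)C1` gives 432000 nM, the highest of the two numbers shown, well apart from compound 1 and beyond the scatter. Compound 2 `Nc1ccc2c(Br)n[nH]c2c1` returns only a limit, > 770000 nM, which is the limit of > 770000 nM in this assay, at which 1 of the 3 values shown sits. Compound 4 `Cn1cc(-c2n[nH]c3ccc(N)cc23)cn1` has not been measured; it differs from compound 3 by amino in place of 3-(methylamino)pyrrolidin-1-yl on an aromatic carbon. Among the measured compounds shown here, no measured pair shows this change, so the expected step from compound 3 to compound 4 is a 1.4-fold higher number from compound 3 to compound 4 (0.14 log units; within the scatter), small and toward weaker inhibition if beyond the scatter at all. Compound 4 is expected at 600000 nM, between 120000 nM and 3000000 nM, with a real chance that only a limit is reported.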

Compound 4, half-maximal inhibitory concentration: 8910 nM
Estimate against measurement, compound 4: 67-fold (1.83 log units) above; measured number below the stated range.
By their numbers in this assay, from the lowest: compound 1; then compound 4; then compound 3. At a limit, above all of these: compound 2.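

On this aromatic carbon, the 3-(methylamino)pyrrolidin-1-yl group is not needed for binding in this assay: replacing it with amino gives a 48-fold lower number from compound 3 to compound 4 (1.69 log units; beyond the scatter). Among the compounds shown here, this pair is the first to isolate the position, and here the ring-free amino group goes with the stronger inhibition. Nothing measured here accounts for the size of this step. On these data alone, whether a methylamino group or an acetamide at this position would match the amino result remains open. Also open, as far as these compounds go, is whether an unsubstituted pyrrolidin-1-yl group would behave like the 3-(methylamino)pyrrolidin-1-yl group.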